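Propoxy to isobutoxy on a pair of esters

The source may report more compounds than this note shows. Statements on the series, on what has been measured and on what is new or still open speak of the compounds shown alone.

Two esters have been measured. Compound 1 `CC1=C(C(=O)OCC(C)C)C(c2ccco2)NC(=O)N1C` gives 13% in an assay on membranes from CHO cells for displacement of a labelled ligand from adenosine receptor A1 (Homo sapiens), read by scintillation counting, with a stated time of 60 min, tested at 1 uM (a lower number here means less inhibition, a higher number more inhibition at the concentration tested (going by the name of the read-out)), and compound 2 `CCCOC(=O)C1=C(C)N(C)C(=O)NC1c1cccs1` gives 9% in this assay. These two numbers lie within the scatter of each other, so the pair shows no difference in inhibition. Compound 3 `CC1=C(C(=O)OCC(C)C)C(c2cccs2)NC(=O)N1C` differs from compound 2 by methyl in place of hydrogen on a saturated chain carbon bound to two saturated chain carbons, which read one bond further out is propoxy to isobutoxy. Because compound 2 sits at 9% near the bottom of the scale, any step in this assay is expected to stay within the scatter, in either direction. The estimated step is a number 3 percentage points higher from compound 2 to compound 3 (within the scatter). Compound 3 is estimated at 12%, between 0% and 28%.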

Compound 3, a percentage reported as inhibition, at one concentration (the size of the read-out at that concentration, not a potency): 9%
The estimate for compound 3 lay 3 percentage points above the measured number; low and high end bracket the measured number.
By their numbers in this assay, from the lowest: compounds 2, 3 and 1 (each within the scatter of the next).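

In this assay, within the data shown here, propoxy to isobutoxy, with thiophen-2-yl held, gives no change at the digits printed from compound 2 to compound 3 (within the scatter) as the first matched reading of this change on the saturated chain carbon. Thiophen-2-yl in place of furan-2-yl on a saturated ring carbon, with isobutoxy held, gives a number 4 percentage points lower from compound 1 to compound 3 (within the scatter) and so neither single change separates from the scatter. No evidence on the cause of either result is available.

As far as these compounds go, whether a longer chain on the ester would raise the inhibition beyond the scatter remains open. The same question stands for phenyl in place of thiophen-2-yl on the saturated ring carbon.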